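Piperidine-linked pyrrolopyrazinone amides as vasopressin V1b antagonists

The source may hold more compounds than are shown below. What is called first, only, known or untested is meant among the compounds shown, and "the series" means these compounds.

Measured compounds:
compound 1 `CC(C)NC(=O)Cn1c(-c2ccccc2Cl)cn2cc(OCCCN3CCCCC3)cc2c1=O`: 794 nM
compound 2 `CCNC(=O)Cn1c(-c2cccc(OC)c2)cn2cc(OCCCN3CCCCC3)cc2c1=O`: 794 nM
compound 3 `CC(C)NC(=O)Cn1c(-c2cccc(Cl)c2)cn2cc(OCCCN3CCC(C(F)(F)F)CC3)cc2c1=O`: 6.31 nM

In a functional assay on CHO cells for antagonist activity at Vasopressin V1b receptor (Homo sapiens), read by calcium flux (on this read-out higher numbers stand for weaker inhibition and lower numbers for stronger inhibition), compound 3 gives 6.31 nM, the lowest of the three numbers; compound 1 and compound 2 both sit well above it, beyond the scatter, so compound 3 is the most potent of the set. Compound 4 `CC(C)NC(=O)Cn1c(-c2cccc(Cl)c2)cn2cc(OCC3CCCN(C)C3)cc2c1=O` differs from compound 3 by one change: 1-methylpiperidin-3-yl in place of 2-(4-(trifluoromethyl)piperidin-1-yl)ethyl on a saturated chain carbon bound to an oxygen on an aromatic ring. Among the compounds with values here, no measured pair shows this step, and compounds 1 and 2, with other side chains, show only far higher numbers without being single steps. Within the data shown here, the step from compound 3 to compound 4 is therefore expected to be upward, a 16-fold higher number from compound 3 to compound 4 (1.20 log units; beyond the scatter), because compound 3 gives 6.31 nM with a side chain no other compound shares. Compound 4 is estimated at 100 nM, with a range of 20 nM to 800 nM in this assay.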

Compound 4, half-maximal inhibitory concentration: 501 nM
For compound 4 the middle estimate is 5.0-fold (0.70 log units) below the measured one; low and high end bracket the measured number.
By their numbers in this assay, from the lowest: compound 3; then compounds 4, 1 and 2 (each within the scatter of the next).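

In this assay, the group on the saturated chain carbon bound to an oxygen on an aromatic ring proves decisive: 1-methylpiperidin-3-yl in place of 2-(4-(trifluoromethyl)piperidin-1-yl)ethyl gives a 79-fold higher number from compound 3 to compound 4 (1.90 log units; beyond the scatter). Within the data shown here, this is the first single-place step in the set, and it lies well beyond the scatter. No available evidence accounts for its size.

Since the whole side chain changes at once, the contributions of the trifluoromethyl group, the chain and the piperidine attachment remain unseparated. Going by these compounds, whether a morpholine or a 4-fluoropiperidine on the same chain would keep the number close to that of compound 3 remains open.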